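The source may hold more compounds than are shown below. What is called first, only, known or untested is meant among the compounds shown, and "the series" means these compounds.

Going by the values given here, compound 2 `COc1cc(-c2nnc3n2NC(c2ccco2)C(C(=O)c2cccc(Br)c2)S3)cc(OC)c1OC` gives 91800 nM in a functional assay on MCF7 cells (Homo sapiens) for cytotoxicity, read by MTT assay, with a stated time of 48 h (a higher number here means a weaker inhibitor, a lower number a stronger inhibitor), the only plain number recorded here. Compound 1 `COc1ccc(C(=O)C2Sc3nnc(-c4cc(OC)c(OC)c(OC)c4)n3NC2c2ccco2)cc1` sits at > 100000 nM in this assay, which is a limit of the assay rather than a number. Among the compounds with values here, the single measured change, an at least 1.0-fold lower number from compound 1 to compound 2 (0.03 log units; that floor lies within the scatter), stays within the scatter. Compound 3 `COc1cc(-c2nnc3n2NC(c2ccco2)C(C(=O)c2ccc(-c4ccccc4)cc2)S3)cc(OC)c1OC` differs from compound 2 by 4-phenylphenyl in place of 3-bromophenyl on a carbonyl carbon. The measured change of one carbonyl-bound aryl group for another did not move the number beyond the scatter, so for compound 3 a step of a 1.0-fold lower number from compound 2 to compound 3 (0.01 log units; within the scatter) in this assay is expected, nothing beyond the scatter. Compound 3 is estimated at 90000 nM, between 30000 nM and 300000 nM.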

Compound 3, half-maximal inhibitory concentration: > 100000 nM
Compound 3: only a limit was reported; the forecaster's own chance of this, stated with the estimate: 45%; middle value at least 1.1-fold (0.04 log units) away from the limit.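

Putting 4-phenylphenyl in place of 3-bromophenyl on the carbonyl carbon gives an at least 1.0-fold higher number from compound 2 to compound 3 (0.03 log units; that floor lies within the scatter) in this assay. Compound 3 gives > 100000 nM, which is a limit of the assay and not a number. From the compounds shown here alone, the second aromatic ring therefore brings no sign of a stronger inhibitor, though how much weaker compound 3 may be stays unknown.

Going by these compounds, the step from compound 1 to compound 3 cannot be read because both values are limits: the limit of > 100000 nM in this assay, at which 2 of the 3 values shown sit. Whether an amine or a carboxylic acid on this aryl ring would lower the number remains open.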